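Adding One Fluoro to a Short-Lived Compound

A few compounds are considered here, and "the series" means these few. Any claim that something is new, unique, unknown or untested is made for them only; others in the source may bear on it.

Compound 1 `CN1C(=O)COc2nc(Nc3cc4c(cn3)ncn4CC3CC3)ccc21` gives 0.65 h
Compound 2 `Cc1cc(Nc2ccc(-n3ccnc3)nc2)nc2c1ncn2CC1CC1` gives 0.333 h

In an ADME assay on microsomes from liver (Rattus norvegicus) for metabolic stability (on this read-out higher numbers stand for a longer-lived compound and lower numbers for a shorter-lived compound), compound 2 stands at 0.333 h and lies within the usual scatter of compound 1 at 0.65 h so neither stands apart. Compound 3 `Cc1c(F)c(Nc2ccc(-n3ccnc3)nc2)nc2c1ncn2CC1CC1` is not yet measured. It differs from compound 2 by fluoro in place of hydrogen on an aromatic carbon on an aromatic carbon, ortho to a methyl group. Within the data shown here, no measured pair shows this change, so no shift beyond the scatter is expected. The estimated step of a 1.2-fold higher number from compound 2 to compound 3 (0.08 log units; within the scatter) is therefore small. Compound 3 is expected at 0.4 h with an estimated range of 0.2 h to 0.8 h in repeat measurements.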

Compound 3, half-life: 0.3 h
Beside the measured number, compound 3's estimate is 1.3-fold (0.12 log units) above it; measured number inside the range.
By their numbers in this assay, from the lowest: compounds 3, 2 and 1 (each within the scatter of the next, the first and the last beyond it).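

Among these compounds, this is the first pair that differs in only one place, so it gives the first direct reading on this position. In this assay, fluoro in place of hydrogen on an aromatic carbon, ortho to a methyl group, gives a 1.1-fold lower number from compound 2 to compound 3 (0.05 log units; within the scatter), so the two compounds cannot be told apart. Nothing measured here offers an explanation for this result.

The compounds shown leave open whether another group at this place, such as chloro, methoxy or an amine, would give a step beyond the scatter. This single pair also cannot say whether fluoro would give a similar step on other aromatic carbons.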